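The source may report more compounds than this note shows. Statements on the series, on what has been measured and on what is new or still open speak of the compounds shown alone.

Measured compounds:
compound 1, `CCCNC(=O)c1c(CN(CC)Cc2ccccc2)nc2ccccc2c1-c1ccccc1`, 872 nM
compound 2, `CCN(CC)C(=O)c1cc(-c2ccccc2)c2ccccc2n1`, 27 nM
compound 3, `CCN(Cc1ccccc1)Cc1ccccc1C(=O)N(C)C`, a limit of the assay, > 10000 nM

In an assay on brain with Translocator protein (Rattus norvegicus) as the target (a lower number here means a stronger inhibitor, a higher number a weaker inhibitor), compound 1 gives 872 nM, the highest of the two numbers that are reported. The nearest number belongs to compound 2, which in this assay gives 27 nM, a gap that lies well beyond the usual scatter. Compound 3 reaches only a limit of the assay, > 10000 nM, and the result the limit of > 10000 nM in this assay, at which 1 of the 3 values shown sits, tells that one of the three values shown sits at that limit, so it is not a number that can be ordered against the others.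

Compound 4, `CCN(Cc1ccccc1)Cc1nc2ccccc2c(-c2ccccc2)c1C(=O)N(C)c1ccccc1`, has not yet been measured in this assay. It differs from compound 1 in one place, (methyl(phenyl)amino in place of propylamino on a carbonyl carbon). The shared core of compound 1 is kept, and the change is confined to the carbonyl carbon whose other neighbour is an aromatic carbon.

Within the data shown here, no step between measured compounds covers this change, so the expectation rests on compound 1 alone and on the spread of the numbers. Compound 4 is expected to give a lower number than compound 1, with the step of a 7.3-fold lower number from compound 1 to compound 4 (0.86 log units; beyond the scatter) beyond the scatter. Compound 4 is estimated at 120 nM in this assay, within a range from 20 nM to 600 nM.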

Compound 4, half-maximal inhibitory concentration: 1320 nM
Beside the measured number, compound 4's estimate is 11-fold (1.04 log units) below it, outside the stated range (above it).
By their numbers in this assay, from the lowest: compound 2; then compounds 1 and 4 (each within the scatter of the next). At a limit, above all of these: compound 3.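

In this assay, putting methyl(phenyl)amino in place of propylamino on the carbonyl carbon gives a 1.5-fold higher number from compound 1 to compound 4 (0.18 log units; within the scatter). Among these compounds, until this pair, no two measured compounds differed in one place, so this is the first reading of this position on its own: a group of more heavy atoms, carrying a six-membered aromatic ring and lacking the hydrogen-bond donor of propylamino, leaves the number where it was, within the scatter. Nothing measured here explains why the two groups read alike, and the one available observation concerns only the limit reached by compound 3, which has no bearing on this change.

On these data alone, it remains open whether a smaller group such as dimethylamino, a longer chain such as hexylamino, or a group carrying a carboxylic acid on the same carbonyl carbon would also leave the number unchanged or would move it beyond the scatter. As far as these compounds go, it also remains open whether the same exchange would read alike on another core, since it is seen here in this single pair only.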